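The source may hold more compounds than are shown below. What is called first, only, known or untested is meant among the compounds shown, and "the series" means these compounds.

In a functional assay on HCT-116 cells (Homo sapiens) for antiproliferative activity, read by MTT assay, with a stated time of 48 h (on this read-out higher numbers stand for weaker inhibition and lower numbers for stronger inhibition), compound 1 `CCCCCCCC(CCO)n1cnc2c(Cl)ncnc21` gives 4160 nM. Compound 3 `CCCCCCCCC(CCO)n1cnc2c(Cl)ncnc21`, which has methyl in place of hydrogen at the end of its saturated chain, gives 1650 nM. Compound 2 `CCCCCCCC(CCO)n1cnc2c(N(C)C)ncnc21` gives > 50000 nM, which is a limit of the assay and not a number. Compound 3 therefore has the lowest of the two actual numbers. The gap behind that standing is modest: a 2.5-fold lower number from compound 1 to compound 3 (0.40 log units; beyond the scatter).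

Compound 4 `CCCCCCCCC(CCO)n1cnc2c(N(C)C)ncnc21` keeps the longer chain of compound 3 but has dimethylamino in place of chloro on an aromatic carbon. Since the same swap on the shorter chain gave the large step of an at least 12-fold higher number from compound 1 to compound 2 (1.07 log units; beyond the scatter), a similarly large rise, meaning much weaker inhibition, is expected in this assay. The modest chain step is too small to offset much of that rise. The expected change is a 24-fold higher number from compound 3 to compound 4 (1.38 log units; beyond the scatter). Compound 4 is estimated at 40000 nM, with an expected range from 18000 nM to 90000 nM.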

Compound 4, half-maximal inhibitory concentration: 19800 nM
The estimate for compound 4 lay 2.0-fold (0.31 log units) above the measured number, within the range that was stated.
By their numbers in this assay, from the lowest: compound 3; then compound 1; then compound 4. At a limit, above all of these: compound 2.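

In this assay, dimethylamino in place of chloro on this aromatic carbon gives a 12-fold higher number from compound 3 to compound 4 (1.08 log units; beyond the scatter), a step with a real number at both ends, and the loss of inhibition appears on both chain lengths: the same change on two cores in this assay, an at least 12-fold higher number (1.07 log units; beyond the scatter) from compound 1 to compound 2 and a 12-fold higher number (1.08 log units; beyond the scatter) from compound 3 to compound 4; the limit leaves it open whether they differ

Compound 2 stands at a limit of the assay, > 50000 nM, so the matching step on the shorter chain could give only a minimum size.

The added chain methyl also still goes with a lower number once dimethylamino is in place, with an at least 2.5-fold lower number from compound 2 to compound 4 (0.40 log units; beyond the scatter): the same change on two cores in this assay, a 2.5-fold lower number (0.40 log units; beyond the scatter) from compound 1 to compound 3 and an at least 2.5-fold lower number (0.40 log units; beyond the scatter) from compound 2 to compound 4; the limit leaves it open whether they differ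

The compounds shown leave open how an amine such as methylamino or an ether such as methoxy would fare on this aromatic carbon. They also leave open whether a still longer chain would lower the number further.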